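Fluoro for Bromo in a Dipeptidyl Peptidase 9 Series

The source may hold more compounds than are shown below. What is called first, only, known or untested is meant among the compounds shown, and "the series" means these compounds.

Compound 1 `CC#CCn1c(N2CCC[C@@H](N)C2)cc(=O)n(Cc2cc(C(=O)OC)ccc2Br)c1=O` and compound 2 `CC#CCn1c(N2CCC[C@@H](N)C2)cc(=O)n(Cc2ccc(Br)c(C(=O)OC)c2)c1=O` share the same atoms joined differently; the difference between the two cores is not broken down here. In an assay on isolated protein for inhibition of Dipeptidyl peptidase 9 (Homo sapiens), read by fluorescence, with stated times of 15 min and 20 min (a lower number here means a stronger inhibitor, a higher number a weaker inhibitor), compound 1 gives only a limit, > 100 nM. Compound 2 likewise gives only a limit in this assay, > 100 nM. Compound 3 `CC#CCn1c(N2CCC[C@@H](N)C2)cc(=O)n(Cc2ccc(F)c(C(=O)OC)c2)c1=O` also returns a limit, > 100 nM. The change fluoro in place of bromo on an aromatic carbon therefore produces a step that the two limits leave unreadable from compound 2 to compound 3. Compound 4 `CC#CCn1c(N2CCC[C@@H](N)C2)cc(=O)n(Cc2cc(C(=O)OC)ccc2F)c1=O` arises from compound 1 by fluoro in place of bromo on an aromatic carbon, the same kind of change, though here the fluoro sits ortho to a large group and para to a methoxycarbonyl group rather than ortho to a methoxycarbonyl group and para to a large group. Because (the limit of > 100 nM in this assay, at which 3 of the 3 values shown sit), compound 4 is expected to follow, with a step that the limit leaves unreadable from compound 1 to compound 4. Compound 4 is thus estimated at 300 nM, most likely reported again as a limit.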

Compound 4, half-maximal inhibitory concentration: > 100 nM
Compound 4: a limit, no number; the forecaster's own chance of this, stated with the estimate: 80%; the middle value is on the limit's open side.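

Going by these compounds alone, compound 1 and compound 4 both return only limits in this assay, so no step between them can be read: the limit of > 100 nM in this assay, at which 4 of the 4 values shown sit. The compounds shown leave open how strongly each one inhibits, and whether fluoro in place of bromo changes that at all.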